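Cytotoxicity notes: from compound 2 to compound 4

The compounds below may be only part of what the source reports. "The series", "measured", "known", "first", "only" and "open" are said of these compounds alone.

Three compounds of this series have been examined in a toxicity assay on THP-1 cells (Homo sapiens) for inhibition; a lower number here means that less compound is tolerated, a higher number that more compound is tolerated. Compound 1 `Cc1ccccc1C(=O)Nc1ncc(-c2ccccc2)n1C` gives in this assay > 100000 nM, which is a limit of the assay and not a number. Compound 2 `COc1ccc(-c2cnc(NC(=O)c3ccc(Br)cc3)n2C)cc1` gives in this assay > 100000 nM, again a limit. Compound 3 `COc1ccc(-c2ccc(NC(=O)c3ccc(F)cc3)nc2)cc1` gives in this assay > 100000 nM, also a limit. Compound 2 thus stands where every measured compound of the series stands, namely at the limit of > 100000 nM in this assay, at which 3 of the 3 values shown sit. Within the data shown here, no two of the measured compounds differ in a single place, so no step between measured values can be read here.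

Compound 4 `COc1ccc(-c2cnc(NC(=O)c3cccc(C#N)c3)n2C)cc1` remains to be measured in this assay. It differs from compound 2 in one place: 3-cyanophenyl in place of 4-bromophenyl on a carbonyl carbon. The amide and the rest of the structure of compound 2 are kept.

With compound 2 sitting at the limit > 100000 nM, no step beyond the scatter is expected from compound 2 to compound 4, and the expected change is a step that the limit leaves unreadable from compound 2 to compound 4. Compound 4 is therefore estimated to give 150000 nM in this assay, with an expected range from 50000 nM to 500000 nM, most probably returned again as a limit rather than a number.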

Compound 4, half-maximal cytotoxic concentration: > 100000 nM
Compound 4 was reported as a limit (the forecaster's own chance of this, stated with the estimate: 85%); the middle value lies beyond the limit too.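

Compound 4 gives > 100000 nM in this assay, again a limit of the assay and not a number. Among these compounds, compound 2 stands at a limit as well, so no step between compound 2 and compound 4 can be read. The compounds shown leave open at what concentration any of them would reach half-maximal cytotoxicity, and whether 3-cyanophenyl in place of 4-bromophenyl changes it: the limit of > 100000 nM in this assay, at which 4 of the 4 values shown sit.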